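The compounds below may be only part of what the source reports. "The series", "measured", "known", "first", "only" and "open" are said of these compounds alone.

Among the compounds with values here, in a functional assay on U-87MG ATCC cells for inhibition, with U-87 MG (Homo sapiens) as the target, read by sulforhodamine B assay, with a stated time of 72 h (a higher number here means that more compound is needed for the effect, a lower number that less compound is needed), only two compounds with a shared core have been measured so far. Within the data shown here, compound 1 `CSc1ccc(C(=O)/C=C/c2ccc([N+](=O)[O-])o2)cc1` gives 3900 nM, and compound 2 `CCCCc1ccc(C(=O)/C=C/c2ccc([N+](=O)[O-])o2)cc1` gives 5800 nM, so compound 2 stands within the scatter of the only other measured compound. Compound 3 `O=C(/C=C/c1ccc([N+](=O)[O-])o1)c1ccc(N2CCCC2)cc1` differs from compound 2 at one place: pyrrolidin-1-yl in place of butyl on an aromatic carbon. Here, pyrrolidin-1-yl replaces butyl on an aromatic carbon, para to a large group. Among the measured compounds shown here, only one measured step bears on this change: a 1.5-fold higher number from compound 1 to compound 2 (0.17 log units; within the scatter), where butyl took the place of methylsulfanyl on that same carbon. That step is small, but it is a single step and does not involve pyrrolidin-1-yl, so the guide is weak. No shift beyond the scatter is expected in either direction, and the expected step is a 1.3-fold lower number from compound 2 to compound 3 (0.11 log units; within the scatter). Compound 3 is estimated at 4500 nM, with an expected range from 1500 nM to 13000 nM.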

Compound 3, half-maximal effective concentration: 35400 nM
Compound 3: middle estimate off by 7.9-fold (0.90 log units), on the low side; measured number above the stated range.
By their numbers in this assay, from the lowest: compounds 1 and 2 (each within the scatter of the next); then compound 3.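

In this assay this place on the aromatic ring, para to a large group, proves sensitive to the group it carries: pyrrolidin-1-yl in place of butyl gives a 6.1-fold higher number from compound 2 to compound 3 (0.79 log units; beyond the scatter) and pyrrolidin-1-yl in place of methylsulfanyl gives a 9.1-fold higher number from compound 1 to compound 3 (0.96 log units; beyond the scatter). Both steps lie beyond the scatter, whereas the earlier exchange of methylsulfanyl for butyl, a 1.5-fold higher number from compound 1 to compound 2 (0.17 log units; within the scatter), did not, so the first two compounds alone gave no sign that this place could matter. Nothing available explains why pyrrolidin-1-yl differs from the other two groups.

The compounds shown leave open whether the higher number goes with the ring or with the nitrogen attached to the aromatic carbon. An open-chain amine such as dimethylamino and a carbon ring such as cyclopentyl at this same place would help separate these two features.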